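Two Limits and One Unmeasured Phenyl Compound

The source may hold more compounds than are shown below. What is called first, only, known or untested is meant among the compounds shown, and "the series" means these compounds.

Compound 1 `COc1cc(-c2cc(-c3ccc(C)cc3)nc(-c3ccccc3)n2)cc(OC)c1OC`: > 25000 nM, a limit
Compound 2 `COc1ccc(-c2cc(-c3cc(OC)c(OC)c(OC)c3)nc(-c3ccccc3)n2)c(OC)c1`: > 25000 nM, a limit

In a functional assay on HT-29 cells (Homo sapiens) for inhibition, read by MTT assay, with a stated time of 48 h (a higher number here means a weaker inhibitor, a lower number a stronger inhibitor), compound 2 gives > 25000 nM, which is a limit and not a number. Both measured compounds sit there, as the limit of > 25000 nM in this assay, at which 2 of the 2 values shown sit, shows. Compound 3 `COc1cc(-c2cc(-c3ccccc3)nc(-c3ccccc3)n2)cc(OC)c1OC` has phenyl in place of 2,4-dimethoxyphenyl on an aromatic carbon. Among the measured compounds shown here, the one measured step, a step that the two limits leave unreadable from compound 1 to compound 2, has no readable size, so it offers no size to carry over, and no step beyond the scatter is expected in this assay. The estimated step is a number no higher from compound 2 to compound 3 (the limit leaves the size open). Compound 3 is expected at about 25000 nM, with an estimated range of 10000 nM to 50000 nM.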

Compound 3, half-maximal inhibitory concentration: 7930 nM
Estimate against measurement, compound 3: 3.2-fold (0.50 log units) above; measured number below the stated range.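

The group at this position can shift the number after all: in this assay, phenyl in place of 2,4-dimethoxyphenyl gives an at least 3.1-fold lower number from compound 2 to compound 3 (0.49 log units; beyond the scatter). Hydrogen in place of methyl on that same ring is enough on its own, with an at least 3.1-fold lower number from compound 1 to compound 3 (0.49 log units; beyond the scatter). Only compound 3 gives a number and not a limit, so the full size of both steps stays open: the limit of > 25000 nM in this assay, at which 2 of the 3 values shown sit.

From the compounds shown here alone, whether the plain phenyl is the best choice here remains open. A fluorine, a hydroxyl or an amine on this ring could lower the number further or raise it again.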